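Thiophen-2-yl in place of 2-fluorophenyl at the imine carbon

This account rests on a few compounds, and the source may have more. Where it says the series, first, only, none or still open, it means among the compounds named here.

Measured so far in a functional assay on HeLa cells (Homo sapiens) for cytotoxicity, read by MTT assay, with a stated time of 48 h, tested at 12.5 uM; a higher number here means a stronger effect of the compound at the concentration tested, a lower number a weaker effect:
compound 1 `CS(=O)(=O)c1ccc(Cc2n[nH]c(=S)n2/N=C/c2c(F)cccc2Cl)cc1` gives 49.8%
compound 2 `CS(=O)(=O)c1ccc(Cc2n[nH]c(=S)n2/N=C/c2ccccc2F)cc1` gives 16.5%

Among the compounds with values here, compound 2 stands lowest of the two numbers; the single measured step, a number 33.3 percentage points lower from compound 1 to compound 2 (beyond the scatter), is large and beyond the scatter. Compound 3 `CS(=O)(=O)c1ccc(Cc2n[nH]c(=S)n2/N=C/c2cccs2)cc1` is the next candidate: thiophen-2-yl in place of 2-fluorophenyl on a carbon with a double bond to nitrogen. Within the data shown here, no measured step touches the group on the carbon double-bonded to nitrogen in this way, so the one known step gives no direct guide, and the expectation rests on compound 2 alone. Compound 3 is therefore expected near its parent, with a step of about a number 1.5 percentage points higher from compound 2 to compound 3 (within the scatter) in this assay , that is no change beyond the scatter. The estimate for compound 3 in this assay is 18%, ranging from 5% to 40%.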

Compound 3, a percentage reported as activity, at one concentration (the size of the read-out at that concentration, not a potency): 28.7%
Beside the measured number, compound 3's estimate is 10.7 percentage points below it; the measured number falls inside the stated range.
By their numbers in this assay, from the lowest: compound 2; then compound 3; then compound 1.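

In this assay, the aromatic ring on the carbon with a double bond to nitrogen can be exchanged outright with a clear effect: thiophen-2-yl gives a number 12.2 percentage points higher from compound 2 to compound 3 (beyond the scatter), but also a number 21.1 percentage points lower from compound 1 to compound 3 (beyond the scatter). Thiophen-2-yl therefore falls between 2-fluorophenyl and 2-chloro-6-fluorophenyl, so a five-membered aromatic ring with a sulfur atom is tolerated here without matching the chloro-bearing ring. Nothing available explains this order. Still open, on these data alone, is how furan-2-yl or pyridin-3-yl would compare at this carbon, and whether a chloro group on the thiophen-2-yl ring would raise the number.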